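Changing the Benzyl Ether: From Compound 3 to Compound 4

The source may report more compounds than this note shows. Statements on the series, on what has been measured and on what is new or still open speak of the compounds shown alone.

Three compounds have been measured in a functional assay on PC-3 cells (Homo sapiens) for cytotoxicity, read by sulforhodamine B assay; on this read-out higher numbers stand for weaker inhibition of growth and lower numbers for stronger inhibition of growth:

Compound 1 `COc1cccc(OC)c1OCCNCCOc1ccccc1OCc1ccc(C)cc1` gives 7800 nM.
Compound 2 `COc1ccccc1COc1ccccc1OCCNCCOc1c(OC)cccc1OC` gives 8900 nM.
Compound 3 `COc1cccc(COc2ccccc2OCCNCCOc2c(OC)cccc2OC)c1` gives 2500 nM.

Compound 3 stands lowest of the three. The steps of a 3.1-fold lower number from compound 1 to compound 3 (0.49 log units; beyond the scatter) and a 3.6-fold lower number from compound 2 to compound 3 (0.55 log units; beyond the scatter) both lie beyond the scatter, so compound 3 is the strongest growth inhibitor measured so far, while compound 1 and compound 2 sit within the scatter of each other (a 1.1-fold higher number from compound 1 to compound 2 (0.06 log units; within the scatter)).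

Compound 4 `CCOc1ccc(COc2ccccc2OCCNCCOc2c(OC)cccc2OC)cc1` differs from compound 3 in one place: 4-ethoxyphenyl in place of 3-methoxyphenyl on a saturated chain carbon bound to an oxygen on an aromatic ring. The two measured steps that bear on this are a 3.1-fold lower number from compound 1 to compound 3 (0.49 log units; beyond the scatter) and a 3.6-fold lower number from compound 2 to compound 3 (0.55 log units; beyond the scatter): in both, arriving at the 3-methoxyphenyl group lowered the number, whether it replaced a 4-methylphenyl or a 2-methoxyphenyl group. Compound 4 gives that group up again for a 4-ethoxyphenyl group; the closest measured comparison is compound 1 with its 4-methylphenyl group, which gives 7800 nM. On this slim basis a modest rise in the number is expected, somewhat short of undoing the whole gain, because the step of a 3.1-fold lower number from compound 1 to compound 3 (0.49 log units; beyond the scatter) sets the scale of what a change at this place has done. Compound 4 is therefore expected to give 5500 nM, within a range of 2200 nM to 14000 nM, an estimated step of a 2.2-fold higher number from compound 3 to compound 4 (0.34 log units; beyond the scatter).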

Compound 4, concentration for 50% growth inhibition: 5200 nM
The estimate for compound 4 lay 1.1-fold (0.02 log units) above the measured number, and the stated range covers the measured number.
By their numbers in this assay, from the lowest: compound 3; then compounds 4, 1 and 2 (each within the scatter of the next).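

In this assay the low number of compound 3 is not kept when 4-ethoxyphenyl replaces 3-methoxyphenyl (a 2.1-fold higher number from compound 3 to compound 4 (0.32 log units; beyond the scatter)), so an oxygen-bearing group on this ring is not enough to hold it; compound 2, with its 2-methoxyphenyl group, shows the same. Among the compounds shown here, compound 4 cannot be told apart from the other two (a 1.7-fold lower number from compound 2 to compound 4 (0.23 log units; within the scatter); a 1.5-fold lower number from compound 1 to compound 4 (0.18 log units; within the scatter)), which leaves 3-methoxyphenyl as the only group of the four that stands apart at this place. Nothing measured here explains why that group differs.

Compound 4 changes both the place of the group on the ring and its length, so 4-methoxyphenyl and 3-ethoxyphenyl would be needed to separate those two changes. From the compounds shown here alone, how a ring bearing an amine or a carboxylic acid would behave at this place also remains open.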